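Lengthening the Alkyl Chain on the Aryl Ketone

The source may hold more compounds than are shown below. What is called first, only, known or untested is meant among the compounds shown, and "the series" means these compounds.

Three compounds have so far been measured in a functional assay on HeLa cells (Homo sapiens) for inhibition; a lower number here means a stronger inhibitor, a higher number a weaker inhibitor:

compound 1, `Cc1ccc(C)c(C(=O)CC(SCC(=O)O)C(=O)O)c1`, gives 2680 nM
compound 2, `Cc1ccc(C(=O)CC(SCC(=O)O)C(=O)O)cc1`, gives 17300 nM
compound 3, `CCc1ccc(C(=O)CC(SCC(=O)O)C(=O)O)cc1`, gives 4790 nM

Among these, compound 3 stands second highest; its number lies within the scatter of that of compound 1 and beyond the scatter from that of compound 2, which is higher. Compound 4, `CCCCc1ccc(C(=O)CC(SCC(=O)O)C(=O)O)cc1`, differs from compound 3 by ethyl in place of hydrogen on a saturated chain carbon, two bonds along the chain from an aromatic carbon. For the measured compounds named here, the one measured step that bears on this change is the earlier lengthening of the same chain, a 3.6-fold lower number from compound 2 to compound 3 (0.56 log units; beyond the scatter). A further lengthening is therefore expected to lower the number in this assay again, though probably by less: a 2.2-fold lower number from compound 3 to compound 4 (0.34 log units; beyond the scatter). Compound 4 is thus estimated at 2200 nM, with a range from 700 nM to 7000 nM.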

Compound 4, half-maximal inhibitory concentration: 1920 nM
Compound 4: middle estimate off by 1.1-fold (0.06 log units), on the high side; the range from low to high includes it.
By their numbers in this assay, from the lowest: compounds 4, 1 and 3 (each within the scatter of the next, the first and the last beyond it); then compound 2.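

In this assay the gain does not stop at ethyl: ethyl in place of hydrogen on a saturated chain carbon, two bonds along the chain from an aromatic carbon, gives a 2.5-fold lower number from compound 3 to compound 4 (0.40 log units; beyond the scatter) and so a second fall beyond the scatter along this chain. Taken whole, going from methyl to butyl amounts to a 9.0-fold lower number from compound 2 to compound 4 (0.95 log units; beyond the scatter) and each lengthening shown lowers the number.

On these data alone, whether a longer chain such as hexyl continues this fall, or a chain ending in an amine keeps it, stays open. Nothing given here explains the trend.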